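This account rests on a few compounds, and the source may have more. Where it says the series, first, only, none or still open, it means among the compounds named here.

In a functional assay on the whole organism (strain Wistar) for inhibition, with Rattus norvegicus as the target, read by paw edema, with stated times of 60 min and 2 h, at a dose of 100 mg/kg by the oral route (on this read-out lower numbers stand for less inhibition and higher numbers for more inhibition at the one dose given (going by the name of the read-out)), the three measured compounds give these numbers:

compound 1 `COc1cc2c(cc1OC)C(CC(=O)N(C)C)CC2`: 36%
compound 2 `CCCCNC(=O)CC1CCc2cc(OC)c(OC)cc21`: 24%
compound 3 `CCCCCNC(=O)CC1CCc2cc(OC)c(OC)cc21`: 34%

Compound 2 stands at the lower end of this set. Its step to compound 3 a number 10 percentage points higher from compound 2 to compound 3 (within the scatter) is within the scatter, whereas the step from compound 1 a number 12 percentage points lower from compound 1 to compound 2 (beyond the scatter) lay beyond it. Compound 4 `COc1cc2c(cc1OC)C(CC(=O)N1CCCCC1)CC2` differs from compound 2 in one place: piperidin-1-yl in place of butylamino on a carbonyl carbon. Within the data shown here, two measured steps bear on this change, since both replace the dimethylamino group of compound 1 on the same carbonyl carbon: a number 12 percentage points lower from compound 1 to compound 2 (beyond the scatter) and a number 2 percentage points lower from compound 1 to compound 3 (within the scatter). Compound 4, like compound 1, carries no hydrogen-bond donor on the amide nitrogen, so a return toward the number of compound 1 is expected, though the evidence is thin and a step of this size sits at the edge of the scatter. Compound 4 is therefore estimated at 33% in this assay, between 18% and 48%, a change of a number 9 percentage points higher from compound 2 to compound 4 (within the scatter) expected to be modest at most.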

Compound 4, a percentage reported as inhibition, in the whole organism at one dose (the size of the read-out at that dose, not a potency): 22%
Compound 4: middle estimate off by 11 percentage points, on the high side; the measured number falls inside the stated range.
By their numbers in this assay, from the lowest: compounds 4, 2, 3 and 1 (each within the scatter of the next, the first and the last beyond it).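

In this assay, piperidin-1-yl on the carbonyl carbon does not bring the number back toward that of compound 1: a number 14 percentage points lower from compound 1 to compound 4 (beyond the scatter) is a step beyond the scatter, while a number 2 percentage points lower from compound 2 to compound 4 (within the scatter) stays within it. The amide hydrogen therefore does not sort this small set, since compound 1 and compound 4 both lack it yet stand apart, whereas compound 2 keeps it and cannot be told from compound 4. The other chain amide also separates, with a number 12 percentage points lower from compound 3 to compound 4 (beyond the scatter) again beyond the scatter, but nothing available accounts for these differences.

Going by these compounds, whether the size of the ring at this position matters stays open, as pyrrolidin-1-yl would show. Whether a ring oxygen, as in morpholin-4-yl, or a longer chain such as hexylamino would shift the number is equally unsettled.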